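The compounds below may be only part of what the source reports. "The series", "measured", "known", "first", "only" and "open" are said of these compounds alone.

Measured so far:
compound 1 `COc1ccc2occ(CSC(=S)N(C(C)C)C(C)C)c(=O)c2c1`: > 40000 nM
compound 2 `COc1ccc2oc(CSC(=S)N3CCOCC3)cc(=O)c2c1`: > 25000 nM
compound 3 `COc1ccc2oc(CSC(=S)N(C(C)C)C(C)C)cc(=O)c2c1`: > 25000 nM

In a functional assay on MCF7 cells (Homo sapiens) for antiproliferative activity, read by MTT assay, with a stated time of 72 h (a higher number here means a weaker inhibitor, a lower number a stronger inhibitor), compound 1 reaches only a limit of the assay, > 40000 nM, not a number. Compound 2 likewise stops at a limit, > 25000 nM. Compound 3 also stops at a limit, > 25000 nM. The change from compound 3 to compound 2 is morpholin-4-yl in place of diisopropylamino on a thiocarbonyl carbon, and its step that the two limits leave unreadable from compound 3 to compound 2 cannot be read because both values sit at the limit of > 25000 nM in this assay, at which 2 of the 3 values shown sit. How the core of compound 1 differs from that of compound 3 is not broken down here. Compound 4 `COc1ccc2occ(CSC(=S)N3CCOCC3)c(=O)c2c1` carries the same change, (morpholin-4-yl in place of diisopropylamino on a thiocarbonyl carbon), on the core of compound 1. Since compound 1 itself sits at the limit of > 40000 nM in this assay, at which 1 of the 3 values shown sits, the step of a number no higher from compound 1 to compound 4 (the limit leaves the size open) is expected to stay unreadable. Compound 4 is therefore estimated at 40000 nM, between 15000 nM and 120000 nM.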

Compound 4, half-maximal inhibitory concentration: 11800 nM
Beside the measured number, compound 4's estimate is 3.4-fold (0.53 log units) above it; the measured number lies below the stated range.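

In this assay, morpholin-4-yl in place of diisopropylamino on a thiocarbonyl carbon gives an at least 3.3-fold lower number from compound 1 to compound 4 (0.53 log units; beyond the scatter), a change beyond the scatter on the core of compound 1. The same change on the core of compound 3, leading to compound 2, cannot be read, because both compounds sit at a limit: the limit of > 25000 nM in this assay, at which 2 of the 4 values shown sit. The lower number is thus shown on one core only, which does not show that the change carries over to the other core, and its full size stays open: the limit of > 40000 nM in this assay, at which 1 of the 4 values shown sits.

Going by these compounds, whether a piperidin-1-yl or dimethylamino group on the thiocarbonyl carbon would give a lower number on either core stays open. So does whether any such group would give a readable number on the core of compound 3.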